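Working notes: replacing 2-cyanophenyl with 4-hydroxyphenyl

A few compounds are considered here, and "the series" means these few. Any claim that something is new, unique, unknown or untested is made for them only; others in the source may bear on it.

Measured in a functional assay on HepG2 cells (Homo sapiens) for inhibition, read by MTT assay, with a stated time of 24 h; a lower number here means a stronger inhibitor, a higher number a weaker inhibitor
- compound 1 `CC1(C)[C@H]2CC[C@]1(C)N(Cc1cn(-c3ccccc3C#N)nn1)C(=O)C2` gives 180 nM
- compound 2 `CC1(C)[C@H]2CC[C@]1(C)N(Cc1cn(-c3ccc(F)cc3)nn1)C(=O)C2` gives 90 nM
- compound 3 `CC1(C)[C@H]2CC[C@]1(C)N(Cc1cn(-c3ccccc3Cl)nn1)C(=O)C2` gives 60 nM

Compound 1 has the highest of the three numbers in this assay, but only compound 3 is clearly separated from it. The nearest is compound 2 (a 2.0-fold lower number from compound 1 to compound 2 (0.30 log units; within the scatter)) and the furthest is compound 3 (a 3.0-fold lower number from compound 1 to compound 3 (0.48 log units; beyond the scatter)). The two replacements are not separated from each other (a 1.5-fold lower number from compound 2 to compound 3 (0.18 log units; within the scatter)).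

Among the compounds with values here, compound 4 `CC1(C)[C@H]2CC[C@]1(C)N(Cc1cn(-c3ccc(O)cc3)nn1)C(=O)C2` has no measurement yet. Its change from compound 1 (4-hydroxyphenyl in place of 2-cyanophenyl on an aromatic nitrogen) is 4-hydroxyphenyl in place of 2-cyanophenyl on an aromatic nitrogen, with the shared core untouched. The two measured steps that also leave 2-cyanophenyl bear directly on it. The 4-fluorophenyl of compound 2 is the closest comparison (a 2.0-fold lower number from compound 1 to compound 2 (0.30 log units; within the scatter)), while the step to the 2-chlorophenyl of compound 3 is the only one beyond the scatter (a 3.0-fold lower number from compound 1 to compound 3 (0.48 log units; beyond the scatter)). Within the data shown here, no measured compound carries 4-hydroxyphenyl, so the size of the step remains uncertain. A modest step towards a lower number is expected, probably not beyond the scatter (a 1.8-fold lower number from compound 1 to compound 4 (0.26 log units; within the scatter)). For compound 4 the estimated value in this assay is 100 nM, with an expected range from 40 nM to 250 nM.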

Compound 4, half-maximal inhibitory concentration: 80 nM
Compound 4: the middle estimate sits 1.3-fold (0.10 log units) above what was measured; measured number inside the range.
By their numbers in this assay, from the lowest: compounds 3, 4, 2 and 1 (each within the scatter of the next, the first and the last beyond it).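

In this assay, the step from 2-cyanophenyl to 4-hydroxyphenyl on the aromatic nitrogen is a 2.3-fold lower number from compound 1 to compound 4 (0.35 log units; beyond the scatter), so compound 4 joins compound 3 as a second replacement clearly separated from compound 1, while the step to compound 2 remains within the scatter. The new group also brings 1 hydrogen-bond donor where 2-cyanophenyl has none, yet hydroxy in place of fluoro gives only a 1.1-fold lower number from compound 2 to compound 4 (0.05 log units; within the scatter), and the change from 2-chlorophenyl gives a 1.3-fold higher number from compound 3 to compound 4 (0.12 log units; within the scatter), so compounds 2, 3 and 4 cannot be ranked against each other at this position. No measurement is available that explains the separation from compound 1 or the lack of separation among the other three.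

From the compounds shown here alone, it remains open whether a methoxy, an amine or a carboxylic acid in place of the hydroxy of compound 4 would stay in the same range of values. An unsubstituted phenyl on the same nitrogen would show whether the hydroxy, fluoro and chloro groups contribute at all, or whether leaving 2-cyanophenyl alone accounts for the lower numbers.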